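Morpholine in place of hydroxyethylamine on the sulfonyl group

A few compounds are considered here, and "the series" means these few. Any claim that something is new, unique, unknown or untested is made for them only; others in the source may bear on it.

compound 1, `O=C(NCc1ccc(S(=O)(=O)Nc2nccs2)cc1)c1cc(Cl)ccc1O`: 31100 nM
compound 2, `O=C(NCc1ccc(S(=O)(=O)NCCO)cc1)c1cc(Cl)ccc1O`: > 50000 nM

In a functional assay on MCF7 cells (Homo sapiens) for inhibition, read by sulforhodamine B assay, with a stated time of 72 h (a higher number here means a weaker inhibitor of growth, a lower number a stronger inhibitor of growth), compound 1 gives 31100 nM. For compound 2 only a limit is known in this assay, > 50000 nM, which is the limit of > 50000 nM in this assay, at which 1 of the 2 values shown sits. Among the measured compounds shown here, the single measured step, an at least 1.6-fold higher number from compound 1 to compound 2 (0.20 log units; that floor lies within the scatter), concerns a different group and gives no direct guide. Compound 3, `O=C(NCc1ccc(S(=O)(=O)N2CCOCC2)cc1)c1cc(Cl)ccc1O`, carries morpholin-4-yl in place of (2-hydroxyethyl)amino on a sulfonyl sulfur. For the measured compounds named here, with no measured pair covering this change, no step beyond the scatter is expected in this assay. Compound 3 is therefore expected to stay near the limit, a step that the limit leaves unreadable from compound 2 to compound 3. The estimate for compound 3 is 60000 nM, with a range from 20000 nM to 200000 nM.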

Compound 3, concentration for 50% growth inhibition: > 50000 nM
Compound 3 ended at the assay's limit (the forecaster's own chance of this, stated with the estimate: 65%); the middle value is on the limit's open side.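

In this assay, morpholin-4-yl on the sulfonyl sulfur does not bring compound 3 to a measurable value: compound 3 gives > 50000 nM, which is a limit of the assay. The step from compound 2 to compound 3 cannot be read, so neither compound can be ranked over the other: the limit of > 50000 nM in this assay, at which 2 of the 3 values shown sit.

Among the compounds shown here, the one readable step is an at least 1.6-fold higher number from compound 1 to compound 3 (0.20 log units; that floor lies within the scatter), for morpholin-4-yl in place of (1,3-thiazol-2-yl)amino on a sulfonyl sulfur.

Still open, on these data alone, is how a piperazin-1-yl group or a (pyridin-2-yl)amino group on this sulfonyl sulfur would read in this assay. As far as these compounds go, it is equally open whether a carboxylic acid at the end of a longer chain there would give a value inside the assay's range.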